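Exchanging the aryl group on an aromatic nitrogen

The source may report more compounds than this note shows. Statements on the series, on what has been measured and on what is new or still open speak of the compounds shown alone.

Compound 1 `COc1ccccc1-n1nncc1CN1C(=O)C2(C(C#N)=C(N)Oc3c(N)cc4nc5ccccc5nc4c32)c2ccccc21` and compound 2 `Cc1ccc(C)c(-n2nncc2CN2C(=O)C3(C(C#N)=C(N)Oc4c(N)cc5nc6ccccc6nc5c43)c3ccccc32)c1` share one core and differ only in the group on an aromatic nitrogen. In a functional assay on HCT-116 cells (Homo sapiens) for antiproliferative activity, read by MTT assay, with a stated time of 48 h (on this read-out lower numbers stand for stronger inhibition and higher numbers for weaker inhibition), compound 1 reaches only the assay limit, > 50000 nM. Compound 2 likewise gives only a limit in this assay, > 50000 nM. The step that the two limits leave unreadable from compound 1 to compound 2 therefore cannot be read. Compound 3 `N#CC1=C(N)Oc2c(N)cc3nc4ccccc4nc3c2C12C(=O)N(Cc1cnnn1-c1ccc(Cl)cc1[N+](=O)[O-])c1ccccc12` carries a further change at that nitrogen, (4-chloro-2-nitrophenyl in place of 2,5-dimethylphenyl on an aromatic nitrogen). For the measured compounds named here, no measured step speaks to this region, and the shared limit of > 50000 nM in this assay, at which 2 of the 2 values shown sit, leaves compound 2 without a numeric standing. Because both values sit at the limit (the limit of > 50000 nM in this assay, at which 2 of the 2 values shown sit), compound 3 is expected to give 50000 nM, within 20000 nM to 150000 nM. The step of a number no higher from compound 2 to compound 3 (the limit leaves the size open) is expected to stay within the scatter.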

Compound 3, half-maximal inhibitory concentration: 28700 nM
Beside the measured number, compound 3's estimate is 1.7-fold (0.24 log units) above it, and the stated range covers the measured number.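

In this assay, for the compounds shown here, compound 3 is the only one of the three compounds at this position to give a number rather than a limit, so the aromatic nitrogen tolerates a change that brings a measurable reading. The exchange for 4-chloro-2-nitrophenyl gives an at least 1.7-fold lower number from compound 2 to compound 3 (0.24 log units; that floor lies within the scatter) and an at least 1.7-fold lower number from compound 1 to compound 3 (0.24 log units; that floor lies within the scatter). The true size of both steps stays open, and the step between compound 1 and compound 2 cannot be read, because those two compounds give only limits: the limit of > 50000 nM in this assay, at which 2 of the 3 values shown sit.

The compounds shown leave open whether the chloro or the nitro group alone would give this reading. They also leave open how a phenyl group bearing an amine or a carboxylic acid would read on that aromatic nitrogen.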